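This account rests on a few compounds, and the source may have more. Where it says the series, first, only, none or still open, it means among the compounds named here.

Of the compounds shown here, three measured so far share a core, and differ only in the two aryl groups attached to it. Compound 1 `COC(=O)N1N=C(c2ccccc2)CC1c1cc(OC)c(OC)c(OC)c1` carries a plain phenyl group and a trimethoxyphenyl group; compound 2 `COC(=O)N1N=C(c2cccc(O)c2)CC1c1cc(OC)c(OC)c(OC)c1` differs from it by one change, (hydrogen in place of hydroxy on an aromatic carbon). Compound 3 `COC(=O)N1N=C(c2ccccc2)CC1c1ccc(OC)c(O)c1` keeps the phenyl group but replaces the trimethoxyphenyl group with a ring bearing one methoxy and one hydroxy group; the difference between the cores of compound 3 and compound 2 is not broken down here.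

In a functional assay on MDA-MB-231 cells (Homo sapiens) for antiproliferative activity, read by MTT assay, with a stated time of 48 h (on this read-out higher numbers stand for weaker inhibition of growth and lower numbers for stronger inhibition of growth), compound 1 gives 1080 nM, and compound 2 gives 740 nM. The step of a 1.5-fold higher number from compound 2 to compound 1 (0.16 log units; within the scatter) is therefore small. Compound 3, however, gives 14500 nM in this assay, the highest number of the three.

Compound 4 `COC(=O)N1N=C(c2ccccc2)CC1c1ccc(OC)cc1` is not yet measured. It differs from compound 3 by hydrogen in place of hydroxy on an aromatic carbon. This is the same kind of change as that from compound 2 to compound 1, though not the same: in compound 3 the hydroxy that leaves sits ortho to a methoxy group, whereas in compound 2 it does not. Since the earlier removal of a hydroxy moved the number only within the scatter, compound 4 is expected to stay near compound 3, and the step of a 1.8-fold lower number from compound 3 to compound 4 (0.26 log units; within the scatter) is estimated to be modest. In this assay compound 4 is estimated at 8000 nM, most likely between 2500 nM and 25000 nM.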

Compound 4, concentration for 50% growth inhibition: > 10000 nM
Compound 4: a limit, no number (the forecaster's own chance of this, stated with the estimate: 5%); at least 1.2-fold (0.09 log units) between middle value and limit.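

Compound 4 gives > 10000 nM in this assay and this is a limit, not a number. The step from compound 3 to compound 4 cannot be read because of that limit: the limit of > 10000 nM in this assay, at which 1 of the 4 values shown sits. The compounds shown leave open whether, and by how much, hydrogen in place of hydroxy changes growth inhibition when the hydroxy sits ortho to a methoxy group.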